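A few compounds are considered here, and "the series" means these few. Any claim that something is new, unique, unknown or untested is made for them only; others in the source may bear on it.

In a functional assay on ECa-109 cells (Homo sapiens) for cytotoxicity, read by MTT assay, with a stated time of 72 h (on this read-out lower numbers stand for stronger inhibition and higher numbers for weaker inhibition), compound 1 `O=C1C(=Cc2ccc(Cl)cc2)C(=O)N(c2ccc(Cl)cc2)N1c1ccc(Cl)cc1` gives 17300 nM, compound 2 `COc1cc(C=C2C(=O)N(c3ccc(Cl)cc3)N(c3ccc(Cl)cc3)C2=O)ccc1O` gives 7100 nM and compound 3 `COc1cccc(C=C2C(=O)N(c3ccc(Cl)cc3)N(c3ccc(Cl)cc3)C2=O)c1OC` gives 6800 nM. Compound 3 thus shares the low end of this small set with compound 2, as a 1.0-fold lower number from compound 2 to compound 3 (0.02 log units; within the scatter) shows. Compound 4 `O=C1C(=Cc2ccc(Cl)cc2Cl)C(=O)N(c2ccc(Cl)cc2)N1c1ccc(Cl)cc1` places 2,4-dichlorophenyl in place of 2,3-dimethoxyphenyl on a double-bonded chain carbon bound to a double-bonded ring carbon. The closest guides are a 2.5-fold lower number from compound 1 to compound 3 (0.41 log units; beyond the scatter) and a 2.4-fold lower number from compound 1 to compound 2 (0.39 log units; beyond the scatter), both modest steps away from 4-chlorophenyl. Compound 4 returns to a chlorine-bearing ring like that of compound 1 at 17300 nM, so a similar step in the opposite direction, towards weaker inhibition in this assay, is expected. The expected change is a 1.9-fold higher number from compound 3 to compound 4 (0.28 log units; within the scatter). For compound 4 the estimated value is 13000 nM, with an expected range of 6000 nM to 28000 nM.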

Compound 4, half-maximal inhibitory concentration: 60200 nM
Compound 4: the middle estimate sits 4.6-fold (0.67 log units) below what was measured, and the stated range ends below it.
By their numbers in this assay, from the lowest: compounds 3 and 2 (each within the scatter of the next); then compound 1; then compound 4.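

In this assay, chloro in place of hydrogen on an aromatic carbon gives a 3.5-fold higher number from compound 1 to compound 4 (0.54 log units; beyond the scatter), so one added chlorine on this ring moves the number clearly towards weaker inhibition. Set against the oxygen-bearing rings, 2,4-dichlorophenyl gives an 8.9-fold higher number from compound 3 to compound 4 (0.95 log units; beyond the scatter) and an 8.5-fold higher number from compound 2 to compound 4 (0.93 log units; beyond the scatter), both larger than any earlier step at this place. Compound 4 therefore has the highest number of the four.

Nothing shown here explains these differences. As far as these compounds go, it also remains open whether a ring carrying an amine or a carboxylic acid would resemble the chlorinated rings or the oxygen-bearing ones.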